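The source may report more compounds than this note shows. Statements on the series, on what has been measured and on what is new or still open speak of the compounds shown alone.

Measured in a functional assay on the whole organism (Tail, strain ICR) with Mus musculus as the target, in the tail flick test, with a stated time of 90 min, at a dose of 25 umol/kg by the oral route; on this read-out higher numbers stand for a stronger effect at the one dose given and lower numbers for a weaker effect:

compound 1 `O=C(CN(c1nc(Cl)nc2[nH]cnc12)C1CC1)N[C@@H](CO)C(=O)OCc1ccccc1`: 34.5%
compound 2 `O=C(CN(c1nc(Cl)nc2[nH]cnc12)C1CC1)N[C@@H](CO)C(=O)O`: 43.9%
compound 3 `O=C(CN(c1ncnc2c1ncn2C1CCCCO1)C1CC1)N[C@@H](CC(=O)OCc1ccccc1)C(=O)OCc1ccccc1`: 25.1%

Compound 2 gives the highest of the three numbers. Compound 1 is the nearest: the step of a number 9.4 percentage points higher from compound 1 to compound 2 (within the scatter) is within the scatter, so the two cannot be ordered. Compound 3 is the furthest off: compound 3 gives 25.1%, and compound 2 gives 43.9%. The gap between those two numbers lies beyond the scatter, but compound 3 differs from compound 2 in several places at once, so no single change can be read out of it.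

Compound 4 `CC(C)C[C@H](NC(=O)CN(c1nc(Cl)nc2[nH]cnc12)C1CC1)C(=O)O` differs from compound 2 in one place: isopropyl in place of hydroxy on a saturated chain carbon, two bonds along the chain from an amide-type nitrogen and a carbonyl carbon. Within the data shown here, no measured pair isolates a change at this saturated chain carbon. Among the measured compounds shown here, the only single-point step on record, a number 9.4 percentage points higher from compound 1 to compound 2 (within the scatter), concerns the oxygen next to the carbonyl group, not this carbon, and was within the scatter; it says nothing about the hydroxy-to-isopropyl exchange. There is thus no ground for expecting a step in this assay beyond the scatter in either direction, and the estimated step is a number 1.9 percentage points lower from compound 2 to compound 4 (within the scatter). For compound 4 the expected value in this assay is 42%, with a range from 24% to 60%.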

Compound 4, a percentage reported as activity, at one dose (the size of the read-out at that dose, not a potency): 27%
Compound 4: middle estimate off by 15 percentage points, on the high side; measured number inside the range.
By their numbers in this assay, from the lowest: compounds 3, 4, 1 and 2 (each within the scatter of the next, the first and the last beyond it).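

In this assay, among these compounds, the exchange of hydroxymethyl for isobutyl gives a number 16.9 percentage points lower from compound 2 to compound 4 (beyond the scatter), whereas the only earlier single-place step, a number 9.4 percentage points higher from compound 1 to compound 2 (within the scatter), concerned the oxygen next to a carbonyl group. This makes the saturated chain carbon, two bonds along the chain from an amide-type nitrogen and a carbonyl carbon, the one place in the series where a single change has moved the read-out beyond the scatter, and hydroxy is the better of the two groups compared there. The change replaces hydroxy, which has a hydrogen-bond donor and acceptor, with isopropyl, which has neither and more heavy atoms, and this one pair cannot separate those differences; nothing on hand accounts for the step.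

A methyl, a longer chain ending in hydroxy, an amine or a carboxylic acid at this carbon would show whether the read-out follows the hydroxy group or the size of the chain. The benzyl ester of compound 4 would show whether the step carries over to the ester form, and all of these readings rest on a single dose.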